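A Furan in Place of Phenyl on the Urea Nitrogen

The compounds below may be only part of what the source reports. "The series", "measured", "known", "first", "only" and "open" are said of these compounds alone.

Measured in a functional assay on Right cardiac atrium for agonist activity at histamine H2 receptor (Cavia porcellus), with a stated time of 30 min, in the presence of a further agent that is not named here; on this read-out lower numbers stand for an effect already at smaller amounts and higher numbers for an effect only at larger amounts of compound:
compound 1 `Cc1nc(N)sc1CCCN/C(N)=N/C(=O)N[C@H](C)c1ccccc1` gives 7.59 nM;
compound 2 `Cc1nc(N)sc1CCCN/C(N)=N/C(=S)N[C@@H](C)c1ccccc1` gives 224 nM;
compound 3 `Cc1nc(N)sc1CCCN/C(N)=N/C(=O)NC(C)c1ccc(Cl)cc1` gives 24.6 nM.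

Among these three, compound 1 has the lowest number; compound 3 sits beyond the scatter above it, and compound 2 lies furthest away. Compound 4 `Cc1nc(N)sc1CCCN/C(N)=N/C(=O)NC(C)c1ccco1` has not yet been measured. It differs from compound 1 in a single place: 1-(furan-2-yl)ethyl in place of 1-phenylethyl on an amide-type nitrogen. Among the compounds with values here, no measured pair shows this exact change, so the size of the step is uncertain; a modest move towards higher numbers in this assay seems most likely, though a step within the scatter cannot be excluded. Compound 4 is therefore expected to give about 15 nM, with a likely range from 5 nM to 45 nM. For compound 4 this amounts to an expected step of a 2.0-fold higher number from compound 1 to compound 4 (0.30 log units; within the scatter).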

Compound 4, half-maximal effective concentration: 9.77 nM
Compound 4: the middle estimate sits 1.5-fold (0.19 log units) above what was measured; the range from low to high includes it.
By their numbers in this assay, from the lowest: compounds 1 and 4 (each within the scatter of the next); then compound 3; then compound 2.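

In this assay, 1-(furan-2-yl)ethyl can take the place of 1-phenylethyl on the amide-type nitrogen with only a 1.3-fold higher number from compound 1 to compound 4 (0.11 log units; within the scatter), so a five-membered aromatic ring with 1 hetero atom is tolerated here. Putting furan-2-yl in place of 4-chlorophenyl gives a 2.5-fold lower number from compound 3 to compound 4 (0.40 log units; beyond the scatter), a modest step. Nothing measured here explains either step.

Going by these compounds, it remains open whether this tolerance extends to other rings, such as 1-(thiophen-2-yl)ethyl or 1-(pyridin-2-yl)ethyl, or to a carboxylic acid or an amine on the furan ring.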